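The compounds below may be only part of what the source reports. "The series", "measured", "known", "first", "only" and "open" are said of these compounds alone.

Measured so far in a functional assay on the whole organism (strain Swiss albino) with Mus musculus as the target, in the maximal electroshock model, with a stated time of 4 h; a lower number here means that less compound is needed, a higher number that more compound is needed for the effect:

- compound 1, `O=C(N/N=C/c1ccc(F)cc1)Nc1cccc2ccccc12`, gives 300 mg/kg
- compound 2, `C/C(=N\NC(=O)Nc1cccc2ccccc12)c1ccc(Cl)cc1`, gives 300 mg/kg
- compound 3, `C/C(=N\NC(=O)Nc1cccc2ccccc12)c1ccc(Cl)cc1Cl`, gives 300 mg/kg

All three compounds share one core and differ only in the group hanging off the far aromatic ring. Compound 1 stands level with compound 2 and compound 3 at the digits shown; none of the three can be placed above or below another, since every gap between them lies within the scatter of this assay.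

Among the compounds with values here, only one measured step exists among them, no change at the digits printed from compound 2 to compound 3 (within the scatter), in which chloro replaces hydrogen on an aromatic carbon. That step did not move the minimum effective dose beyond the scatter.

Compound 4, `O=C(N/N=C/c1ccc([N+](=O)[O-])cc1)Nc1cccc2ccccc12`, has not yet been tested. It differs from compound 1 as follows: nitro in place of fluoro on an aromatic carbon. Within the data shown here, no measured pair swaps fluoro for nitro, so nothing bears directly on this change; the one step that does exist, adding a group on the same kind of aromatic ring, gave no change. On that basis the expected step from compound 1 to compound 4 in this assay is none beyond the scatter, no change at the digits printed from compound 1 to compound 4 (within the scatter). Compound 4 is therefore estimated at 300 mg/kg, with a range from 150 mg/kg to 600 mg/kg.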

Compound 4, minimum effective dose: 300 mg/kg
Estimate against measurement, compound 4: no gap at the digits printed, within the range that was stated.
By their numbers in this assay, from the lowest: compounds 1, 2, 3 and 4 (each within the scatter of the next).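

In this assay, nitro in place of fluoro on an aromatic carbon, para to a large group, gives no change at the digits printed from compound 1 to compound 4 (within the scatter). The earlier step showed only that adding chloro in place of hydrogen left the dose within the scatter, whereas this one exchanges one group for another at this position: nitro brings 3 heavy atoms and 2 hydrogen-bond acceptors where fluoro brings 1 heavy atom and no acceptor, and that difference does not show in the read-out. No measured information here explains why the minimum effective dose stays within the scatter across this exchange.

The compounds shown leave open whether an amine, a carboxylic acid or a longer chain such as butyl at this same position would move the dose beyond the scatter, or whether the read-out would stay where it is for those groups too. They also leave open whether nitro in place of fluoro would read the same on the core of compound 2, which carries a methyl group that compound 1 lacks.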